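A new group on the amide-type nitrogen of compound 3

The compounds below may be only part of what the source reports. "The series", "measured", "known", "first", "only" and "open" are said of these compounds alone.

Compound 1 `C[C@H](NC(=O)c1nc(Br)c2cccnc2c1N[C@H]1CC[C@H](N)CC1)c1ccc(F)cc1`: 9000 nM
Compound 2 `N[C@H]1CC[C@H](Nc2c(C(=O)NCc3ccc(Cl)cc3)nc(Br)c3cccnc23)CC1`: 2000 nM
Compound 3 `N[C@H]1CC[C@H](Nc2c(C(=O)NCc3cccs3)nc(Br)c3cccnc23)CC1`: "not determined" (no result reported)

These results come from a functional assay on SK-BR-3 cells (Homo sapiens) for cytotoxicity, read by MTT assay, with a stated time of 72 h; on this read-out lower numbers stand for stronger inhibition and higher numbers for weaker inhibition. Compound 3 has no number to stand on, as its entry reads "not determined" (no result reported), so it cannot be ranked against the other two compounds. The next compound, compound 4 `N[C@H]1CC[C@H](Nc2c(C(=O)Nc3ccccc3)nc(Br)c3cccnc23)CC1`, keeps the shared core and carries phenyl in place of (thiophen-2-yl)methyl on an amide-type nitrogen.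

Going by the values given here, only one measured step bears on this change. It also swaps a group on an amide-type nitrogen, and it gives a 4.5-fold lower number from compound 1 to compound 2 (0.65 log units; beyond the scatter). That modest step lies beyond the usual scatter, so the group at this place can shift the read-out. Among the compounds with values here, it involves neither phenyl nor (thiophen-2-yl)methyl, however, and no measured compound shows the effect of either group. With no starting number, no size or direction can be expected for the step from compound 3 itself. The expectation therefore rests on the range set by compound 2 at 2000 nM and compound 1 at 9000 nM, widened to allow for the untested group. For compound 4 the expected value is about 4000 nM, with an estimated range from 1000 nM to 15000 nM.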

Compound 4, half-maximal inhibitory concentration: 2000 nM
For compound 4 the middle estimate is 2.0-fold (0.30 log units) above the measured one; the measured number falls inside the stated range.
By their numbers in this assay, from the lowest: compounds 2 and 4 (each within the scatter of the next); then compound 1.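

In this assay, the step of no change at the digits printed from compound 2 to compound 4 (within the scatter) shows that phenyl on the amide-type nitrogen reads the same as 4-chlorobenzyl, so among these compounds neither the chlorine nor the extra carbon of the benzyl group is needed to reach this level. The step of a 4.5-fold lower number from compound 1 to compound 4 (0.65 log units; beyond the scatter) adds a second group that gives a lower number than 1-(4-fluorophenyl)ethyl, which makes compound 1 the one that stands apart among the three measured compounds, while compound 2 and compound 4 cannot be told apart. The change from (thiophen-2-yl)methyl to phenyl itself cannot be read, as compound 3 has no number to start from.

No measurement shown here explains why these groups give the numbers they do. Still open, going by these compounds, is how a longer chain such as 2-phenylethyl, or a phenyl carrying an amine or a carboxylic acid, would read on this nitrogen, and whether any group at this place can improve on compound 4 at 2000 nM.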